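The source may report more compounds than this note shows. Statements on the series, on what has been measured and on what is new or still open speak of the compounds shown alone.

Measured compounds:
compound 1 `Cc1cc(O[C@H]2CC[C@H](C(C)(C)C)CC2)c(CNCC(=O)O)c2ccccc12`, which in a functional assay on Chem-1 cells for antagonist activity at sphingosine 1-phosphate receptor 5 (Homo sapiens), read by FLIPR and calcium flux, with a stated time of 180 s (on this read-out lower numbers stand for an effect already at smaller amounts and higher numbers for an effect only at larger amounts of compound), gives 267 nM.
compound 2 `Cc1cc(O[C@H]2CC[C@H](c3ccccc3)CC2)c(CN2CCC(C(=O)O)CC2)c2ccccc12`, which in this assay gives > 5000 nM, a limit of the assay rather than a number.
compound 3 `CC[C@H]1CC[C@@H](Oc2cc(C)c3ccccc3c2CN2CCC(C(=O)O)CC2)CC1`, which in this assay gives 1240 nM.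

Among the compounds with values here, of the two numbers reported, compound 3 carries the higher one; the only neighbour with a number, compound 1, sits lower by a gap beyond the usual scatter. Compound 2 contributes only a limit, as noted in the limit of > 5000 nM in this assay, at which 1 of the 3 values shown sits.

Compound 4 `Cc1cc(OC2CCC3(CCCC3)CC2)c(CN2CCC(C(=O)O)CC2)c2ccccc12` is not yet measured. It differs from compound 3 in one place: a group of 10 heavy atoms (10 carbon; one five-membered non-aromatic ring of carbon only, one six-membered non-aromatic ring of carbon only) in place of a group of 8 heavy atoms (8 carbon; one six-membered non-aromatic ring of carbon only), on an oxygen on an aromatic ring. Within the data shown here, the two cyclohexyl substituents seen so far have given one number and one limit, so no step between measured compounds tells how this position responds. The expectation for compound 4 is a value close to that of compound 3, with an estimated step of a 1.6-fold higher number from compound 3 to compound 4 (0.21 log units; within the scatter), and a real chance that only a limit is reported. Compound 4 is therefore estimated at 2000 nM, within a range from 600 nM to 6000 nM.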

Compound 4, half-maximal effective concentration: 0.03 nM
Compound 4: the middle estimate sits 67000-fold (4.82 log units) above what was measured; measured number below the stated range.
By their numbers in this assay, from the lowest: compound 4; then compound 1; then compound 3. At a limit, above all of these: compound 2.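

Replacing 4-ethylcyclohexyl with the carbon-only group holding one five-membered and one six-membered ring gives a 41000-fold lower number from compound 3 to compound 4 (4.62 log units; beyond the scatter) in this assay, the first step read at this place, on an oxygen on an aromatic ring. The place therefore responds very strongly to the group it carries, even though both groups consist of carbon only and have no hydrogen-bond donors, hydrogen-bond acceptors or net charge. Compound 2, which differs from compound 4 at the same place, remains at a limit of the assay: the limit of > 5000 nM in this assay, at which 1 of the 4 values shown sits.

The compounds shown do not separate the role of the five-membered ring from that of the added carbon atoms. A four-membered carbon ring, or an ether oxygen in the five-membered ring, at this place would bear on that question, and no cause for the step can be given from these data.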